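The source may hold more compounds than are shown below. What is called first, only, known or untested is meant among the compounds shown, and "the series" means these compounds.

Compound 1 `COc1ccc(/C=C/c2cc(OC)c(OC)c(OC)c2-c2ccc(OC)cc2)cc1`: 36000 nM
Compound 2 `COc1ccc(/C=C/c2cc(OC)c(OC)c(OC)c2-c2ccc3ccccc3c2)cc1`: 16000 nM
Compound 3 `COc1ccc(/C=C/c2cc(OC)c(OC)c(OC)c2-c2ccc(Cl)cc2)cc1`: 15000 nM

In a functional assay on SK-N-SH cells (Homo sapiens) for cytotoxicity, read by MTT assay, with a stated time of 48 h (a lower number here means a stronger inhibitor, a higher number a weaker inhibitor), compound 3 stands level with compound 2, with a 1.1-fold lower number from compound 2 to compound 3 (0.03 log units; within the scatter), and both numbers lie under that of compound 1, with a 2.4-fold lower number from compound 1 to compound 3 (0.38 log units; beyond the scatter) and a 2.3-fold lower number from compound 1 to compound 2 (0.35 log units; beyond the scatter). Compound 4 `COc1ccc(/C=C/c2cc(OC)c(OC)c(OC)c2-c2ccc(F)c(C)c2)cc1` changes one group of compound 3: 4-fluoro-3-methylphenyl in place of 4-chlorophenyl on an aromatic carbon. Among the measured compounds shown here, no measured step covers 4-fluoro-3-methylphenyl itself. The nearest guides are the modest steps away from compound 1 and the step within the scatter between compound 2 and compound 3, so no step beyond the scatter is expected in this assay. An estimated 1.1-fold higher number from compound 3 to compound 4 (0.05 log units; within the scatter) is therefore expected. For compound 4 the expected value is 17000 nM, with an estimated range from 8000 nM to 34000 nM.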

Compound 4, half-maximal inhibitory concentration: 19000 nM
For compound 4 the middle estimate is 1.1-fold (0.05 log units) below the measured one, and the stated range covers the measured number.
By their numbers in this assay, from the lowest: compounds 3, 2, 4 and 1 (each within the scatter of the next, the first and the last beyond it).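

In this assay, this position accepts 4-fluoro-3-methylphenyl with no step beyond the scatter from the two nearest compounds (a 1.3-fold higher number from compound 3 to compound 4 (0.10 log units; within the scatter); a 1.2-fold higher number from compound 2 to compound 4 (0.07 log units; within the scatter)). Unlike the replacements in compound 2 and compound 3, this change from 4-methoxyphenyl stays within the scatter (a 1.9-fold lower number from compound 1 to compound 4 (0.28 log units; within the scatter)), so the separation from compound 1 seen earlier does not hold for every replacement. Nothing available explains these numbers. As far as these compounds go, what an amine or a carboxylic acid on this ring would do at this position remains open, as does a saturated ring in place of the aromatic one.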